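The source may report more compounds than this note shows. Statements on the series, on what has been measured and on what is new or still open speak of the compounds shown alone.

Measured compounds:
- compound 1 `Cc1ccc(Nc2nc(Cl)nc3c2ncn3Cc2ccc(C(=O)Nc3ccccc3N)cc2)cc1`: 82.5%
- compound 2 `Cc1ccc(Nc2nc(Cl)nc3c2ncn3Cc2ccc(/C=C/C(=O)Nc3ccccc3N)cc2)cc1`: 51.3%
- compound 3 `CCCCn1cnc2c(Nc3ccccc3)nc(NCOCc3ccc(/C=C/C(=O)Nc4ccccc4N)cc3)nc21`: 34.2%

Three compounds were measured in a functional assay on NCI-H460 cells (Homo sapiens) for antiproliferative activity, read by CCK-8 assay, with a stated time of 72 h, tested at 8 uM; on this read-out lower numbers stand for a weaker effect and higher numbers for a stronger effect at the one concentration tested. Compound 1 gives 82.5% in this assay, compound 2 gives 51.3%, and compound 3 gives 34.2%, the lowest of the three. Compound 1 and compound 2 share one core and differ in a single place: (2-aminophenyl)carbamoyl in place of 2-((2-aminophenyl)carbamoyl)ethenyl on an aromatic carbon. This change made a step of a number 31.2 percentage points higher from compound 2 to compound 1 (beyond the scatter). Compound 3 rests on a different core; the difference between the two cores and that of compound 2 is not broken down here.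

Compound 4 `CCCCn1cnc2c(Nc3ccccc3)nc(NCOCc3ccc(C(=O)Nc4ccccc4N)cc3)nc21` is not yet measured. It stands to compound 3 as compound 1 stands to compound 2, with the same change in the same place: (2-aminophenyl)carbamoyl in place of 2-((2-aminophenyl)carbamoyl)ethenyl on an aromatic carbon. Among the measured compounds shown here, because the only measured example of this change, a number 31.2 percentage points higher from compound 2 to compound 1 (beyond the scatter), was large and in the upward direction, a step of similar direction is expected from compound 3 to compound 4, though the other core gives no assurance of its size; the expected step is a number 23.8 percentage points higher from compound 3 to compound 4 (beyond the scatter). Compound 4 is therefore estimated at 58% in this assay, with a likely range from 40% to 78%.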

Compound 4, a percentage reported as inhibition, at one concentration (the size of the read-out at that concentration, not a potency): 51.3%
Estimate against measurement, compound 4: 6.7 percentage points above, and the stated range covers the measured number.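

In this assay, putting (2-aminophenyl)carbamoyl in place of 2-((2-aminophenyl)carbamoyl)ethenyl on the second core gives a number 17.1 percentage points higher from compound 3 to compound 4 (beyond the scatter), so the direction seen on the first core carries over. The size of the step does not carry over, and the two steps differ: the same change on two cores in this assay, a number 31.2 percentage points higher (beyond the scatter) from compound 2 to compound 1 and a number 17.1 percentage points higher (beyond the scatter) from compound 3 to compound 4, 14.1 percentage points apart, beyond the scatter of two such steps. This shows that on these two cores the direction held while the size depended on the core, but it does not show which part of the cores sets the gap, whether the direction would hold on a third core, or whether the stronger effect would hold at other concentrations, as each number comes from a single concentration.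

The compounds shown leave open whether a saturated chain in place of the ethenyl link would fall in with either pair, and what a hydroxamic acid would do in place of the 2-aminophenyl amide. They also leave open whether an amine in place of the chlorine on the core of compound 1 would change the size of the step.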